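The source may hold more compounds than are shown below. What is called first, only, known or untested is meant among the compounds shown, and "the series" means these compounds.

For the measured compounds named here, in a functional assay on HepG2 cells (Homo sapiens) for inhibition, read by MTT assay, with a stated time of 24 h (on this read-out lower numbers stand for stronger inhibition and higher numbers for weaker inhibition), compound 1 `CC1(C)[C@H]2CC[C@]1(C)N(Cc1cn(-c3ccccc3Br)nn1)C(=O)C2` gives 150 nM and compound 2 `CC1(C)[C@H]2CC[C@]1(C)N(Cc1cn(-c3cccc(Cl)c3)nn1)C(=O)C2` gives 60 nM as the lower of the two numbers so far. Compound 3 `CC1(C)[C@H]2CC[C@]1(C)N(Cc1cn(-c3ccccc3)nn1)C(=O)C2` is not yet measured. The change from compound 2 reads hydrogen in place of chloro on an aromatic carbon and amounts to hydrogen in place of chloro on an aromatic carbon, so 3-chlorophenyl becomes phenyl. Going by the values given here, only one measured step bears on this, and it is modest: a 2.5-fold lower number from compound 1 to compound 2 (0.40 log units; beyond the scatter) on exchanging 2-bromophenyl for 3-chlorophenyl. Among the compounds with values here, no measured pair shows a halogen simply removed, so that step is an indirect guide. A step of similar modest size toward a higher number is expected in this assay from this single comparison. The estimated step is a 1.8-fold higher number from compound 2 to compound 3 (0.26 log units; within the scatter) on these grounds. For compound 3 the estimated value is 110 nM with an expected range from 40 nM to 300 nM on this read-out.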

Compound 3, half-maximal inhibitory concentration: 90 nM
Compound 3: middle estimate off by 1.2-fold (0.09 log units), on the high side; the measured number falls inside the stated range.
By their numbers in this assay, from the lowest: compounds 2, 3 and 1 (each within the scatter of the next, the first and the last beyond it).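

In this assay, for the compounds shown here, the phenyl of compound 3 gives the first direct reading of halogen against hydrogen on this ring, with a 1.5-fold higher number from compound 2 to compound 3 (0.18 log units; within the scatter) for hydrogen in place of chloro. For hydrogen in place of bromo the reading is a 1.7-fold lower number from compound 1 to compound 3 (0.22 log units; within the scatter) and so neither halogen stands apart from hydrogen, while the gap between compound 1 and compound 2 lies beyond the scatter only as the sum of these two steps. Nothing measured alongside these numbers accounts for them. The compounds shown leave open whether the identity of the halogen or its place on the ring goes with the gap between compound 1 and compound 2. Also open, on these data alone, is how this assay reads a non-halogen group on the ring, such as a methoxy group or an amine.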